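Swapping the anilide ring of a thiadiazole amide

This account rests on a few compounds, and the source may have more. Where it says the series, first, only, none or still open, it means among the compounds named here.

Measured so far:
compound 1 `O=C(CSc1snnc1-c1ccc(Cl)cc1Cl)Nc1ccccc1Br`: >= 146000 nM
compound 2 `O=C(CSc1snnc1-c1ccc(F)cc1F)Nc1ccccc1F`: 148000 nM

In an ADME assay on MT4 cells (Homo sapiens) for cytotoxicity (a higher number here means that more compound is tolerated, a lower number that less compound is tolerated), compound 1 gives >= 146000 nM, which is a limit of the assay and not a number. In this assay compound 2 gives 148000 nM, the only number shown, sitting close to the limit of >= 146000 nM in this assay, at which 1 of the 2 values shown sits. Compound 3 `Cc1ccc(NC(=O)CSc2snnc2-c2ccc(F)cc2F)c(Br)c1` is not yet measured; it differs from compound 2 by 2-bromo-4-methylphenyl in place of 2-fluorophenyl on an amide-type nitrogen. Going by the values given here, no step between measured compounds is available, so no change beyond the scatter in this assay is expected. Compound 3 is estimated at 140000 nM, between 70000 nM and 200000 nM. The expected step is a 1.1-fold lower number from compound 2 to compound 3 (0.02 log units; within the scatter), within the usual scatter.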

Compound 3, half-maximal cytotoxic concentration: > 273000 nM
Compound 3 ended at the assay's limit; the forecaster's own chance of this, stated with the estimate: 50%; at least 1.9-fold (0.29 log units) between middle value and limit.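

In this assay, putting 2-bromo-4-methylphenyl in place of 2-fluorophenyl on the amide-type nitrogen gives an at least 1.8-fold higher number from compound 2 to compound 3 (0.26 log units; that floor lies within the scatter). Compound 3 gives > 273000 nM, which is a limit of the assay and not a number. This is the first comparison shown that changes only this one place, and it shows no drop in the amount of compound tolerated.

Going by these compounds, the true value of compound 3 stays unknown, so the full size of the step cannot be read. On these data alone, whether a phenyl ring bearing an amine or a carboxylic acid would be tolerated as well also remains open.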